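Acetyl for Methoxy: Expected Change in Cell Inhibition

This account rests on a few compounds, and the source may have more. Where it says the series, first, only, none or still open, it means among the compounds named here.

compound 1 `Brc1cn2ccnc2c(-c2ccc3ncn(C4CCCCC4)c3c2)n1`: 16.2%
compound 2 `COc1ccc(-c2cn3ccnc3c(-c3ccc4ncn(C5CCCCC5)c4c3)n2)cc1`: -20.9%
compound 3 `O=Cc1ccc(-c2cn3ccnc3c(-c3ccc4ncn(C5CCCCC5)c4c3)n2)cc1`: 25.3%

In a functional assay on NCI-H522 cells (Homo sapiens) for inhibition, read by sulforhodamine B assay, with a stated time of 48 h, tested at 10 uM (on this read-out higher numbers stand for more inhibition at the one concentration tested (going by the name of the read-out) and lower numbers for less inhibition), compound 2 stands lowest of the three numbers. Its nearest neighbour is compound 1, separated by the step of a number 37.1 percentage points lower from compound 1 to compound 2 (beyond the scatter); its furthest is compound 3, separated by the step of a number 46.2 percentage points higher from compound 2 to compound 3 (beyond the scatter). Compound 4 `CC(=O)c1ccc(-c2cn3ccnc3c(-c3ccc4ncn(C5CCCCC5)c4c3)n2)cc1` differs from compound 2 by acetyl in place of methoxy on an aromatic carbon. The measured step that bears on this is a number 46.2 percentage points higher from compound 2 to compound 3 (beyond the scatter), where a formyl replaced the same methoxy. Acetyl is the closely related change, so a rise beyond the scatter is expected, though its size is uncertain. The expected step is a number 35.9 percentage points higher from compound 2 to compound 4 (beyond the scatter). Compound 4 is therefore estimated at 15%, within a range from -12% to 40%.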

Compound 4, a percentage reported as inhibition, at one concentration (the size of the read-out at that concentration, not a potency): 10.4%
Beside the measured number, compound 4's estimate is 4.6 percentage points above it; low and high end bracket the measured number.
By their numbers in this assay, from the lowest: compound 2; then compounds 4, 1 and 3 (each within the scatter of the next, the first and the last beyond it).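

In this assay acetyl repeats what formyl did at this position, with a number 31.3 percentage points higher from compound 2 to compound 4 (beyond the scatter) as the step, while adding methyl to the carbonyl carbon gives a number 14.9 percentage points lower from compound 3 to compound 4 (beyond the scatter) as a smaller step back. The 4-acetylphenyl group cannot be told apart from bromo, since a number 5.8 percentage points lower from compound 1 to compound 4 (within the scatter) is the step between them. No evidence at hand accounts for these differences.

On these data alone, whether a carboxylic acid or an aminomethyl group in the same place would match the formyl compound remains open. So does whether a longer chain on the carbonyl, such as propanoyl, would lower the number further.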